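Growth inhibition notes: a trihydroxyphenyl group on compound 3

The source may report more compounds than this note shows. Statements on the series, on what has been measured and on what is new or still open speak of the compounds shown alone.

In a functional assay on DU-145 cells (Homo sapiens) for inhibition, read by trypan blue exclusion, with a stated time of 96 h (on this read-out lower numbers stand for stronger inhibition of growth and higher numbers for weaker inhibition of growth), compound 1 `CSc1ccc(/C=C(\C(=O)c2ccc(Cl)cc2)S(=O)(=O)Cc2ccc(C)cc2)cc1` reads (10000 nM) and compound 3 `Cc1ccc(CS(=O)(=O)/C(=C/c2sccc2C)C(=O)c2ccc(Cl)cc2)cc1` reads (25000 nM), the higher of the two numbers available. For the measured compounds named here, the one measured step between them is modest and beyond the scatter (a 2.5-fold higher number from compound 1 to compound 3 (0.40 log units; beyond the scatter)). It swaps 4-(methylsulfanyl)phenyl for 3-methylthiophen-2-yl at the same place, so it gives a size for a change at this place but does not involve the new group.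

The next change leads to compound 4 `Cc1ccc(CS(=O)(=O)/C(=C/c2c(O)cc(O)cc2O)C(=O)c2ccc(Cl)cc2)cc1` and reads (2,4,6-trihydroxyphenyl in place of 3-methylthiophen-2-yl on a double-bonded chain carbon bound to a double-bonded chain carbon). The expectation of weaker inhibition leans on compound 2 `O=C(/C(=C\c1c(O)cc(O)cc1O)S(=O)(=O)c1ccc(Br)cc1)c1ccc(Cl)cc1`, which carries the same 2,4,6-trihydroxyphenyl group and gives (> 100000 nM), a limit of the assay and not a number. Compound 2 also differs from compound 4 elsewhere, so this is only a weak guide.

For compound 4 a modest step to a higher number is expected (a 2.4-fold higher number from compound 3 to compound 4 (0.38 log units; beyond the scatter)). The estimated value for compound 4 is 60000 nM, with an expected range from 15000 nM to 100000 nM.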

Compound 4, concentration for 50% growth inhibition: > 100000 nM
Compound 4 ended at the assay's limit (the forecaster's own chance of this, stated with the estimate: 35%); at least 1.6-fold (0.22 log units) between middle value and limit.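

At this place, on a double-bonded chain carbon bound to a double-bonded chain carbon, 2,4,6-trihydroxyphenyl gives an at least 4.0-fold higher number from compound 3 to compound 4 (0.60 log units; beyond the scatter) and an at least 10-fold higher number from compound 1 to compound 4 (1.00 log units; beyond the scatter), so in this assay the new group reads weaker than either earlier group, and the size of that loss has only a lower bound. Compound 4 gives > 100000 nM, which is a limit of the assay and not a number. The step between compound 2 and compound 4 cannot be read, and 4-methylbenzyl in place of 4-bromophenyl on the sulfonyl sulfur stays without a size, because both compounds sit at the same bound: the limit of > 100000 nM in this assay, at which 2 of the 4 values shown sit.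

The compounds shown leave open how far the 2,4,6-trihydroxyphenyl compounds lie past that limit. They also leave open whether a phenyl ring with a single hydroxyl group, or with methoxy groups in place of the hydroxyl groups, would read closer to compound 1 or to compound 4.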